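The source may hold more compounds than are shown below. What is called first, only, known or untested is meant among the compounds shown, and "the series" means these compounds.

Measured compounds in a functional assay on MGC-803 cells (Homo sapiens) for inhibition, read by MTT assay, with a stated time of 72 h; on this read-out lower numbers stand for stronger inhibition and higher numbers for weaker inhibition:
Compound 1 `O=C(CSc1nc(Nc2ccccc2)c2ccccc2n1)Nc1ccccc1Br`: compound 1 gives 18600 nM.
Compound 2 `O=C(CSc1nc(Nc2ccccc2)c2ccccc2n1)Nc1ccc(Br)cc1`: compound 2 gives 19300 nM.

Going by the values given here, compound 2 holds the higher of the two numbers in this assay, but the only step between measured compounds, a 1.0-fold higher number from compound 1 to compound 2 (0.02 log units; within the scatter), is within the scatter, so the two compounds are not separated by the data.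

Compound 3 `O=C(CSc1nc(Nc2ccccc2)c2ccccc2n1)Nc1ccc([N+](=O)[O-])cc1` differs from compound 2 by nitro in place of bromo on an aromatic carbon. Among the compounds with values here, no measured step exchanges bromo for nitro. Within the data shown here, the single step available, a 1.0-fold higher number from compound 1 to compound 2 (0.02 log units; within the scatter), exchanges one bromophenyl for another and is within the scatter, so it offers no direct guide to this change; it shows only that changes at this phenyl have so far left this assay unmoved. The step expected from compound 2 to compound 3 is therefore none beyond the scatter, a 1.0-fold lower number from compound 2 to compound 3 (0.01 log units; within the scatter). For compound 3 the estimate in this assay is 19000 nM, with a range from 7500 nM to 48000 nM.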

Compound 3, half-maximal inhibitory concentration: > 50000 nM
Compound 3 gave a limit, no number (the forecaster's own chance of this, stated with the estimate: 5%); at least 2.6-fold (0.42 log units) between middle value and limit.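

In this assay compound 3 gives a limit and not a number: the limit of > 50000 nM in this assay, at which 1 of the 3 values shown sits. Changing the group on this phenyl does move the read-out, with an at least 2.5-fold higher number from compound 2 to compound 3 (0.41 log units; beyond the scatter) for nitro in place of bromo and an at least 2.6-fold higher number from compound 1 to compound 3 (0.42 log units; beyond the scatter) for 4-nitrophenyl in place of 2-bromophenyl, whereas moving the bromo gave only a 1.0-fold higher number from compound 1 to compound 2 (0.02 log units; within the scatter). From the compounds shown here alone, both new steps are bounded on one side only, so their full size is unknown.

The three compounds cannot show whether the weaker inhibition belongs to nitro alone or would also come with an amine, a methoxy group or a carboxylic acid on this aromatic carbon. Nor do they show whether the nitro group would behave the same way as 2-nitrophenyl, the arrangement in which the bromo of compound 1 sits.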